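This account rests on a few compounds, and the source may have more. Where it says the series, first, only, none or still open, it means among the compounds named here.

Three compounds built on a shared core have been examined, and a fourth awaits its number. Compound 1 `O=c1cc(CC(O)(COCc2ccccc2)COCc2ccccc2)[nH]c(=O)[nH]1` reaches only the limit of a functional assay on SW-620 cells (Homo sapiens) for antiproliferative activity, read by MTT assay, with a stated time of 72 h (a lower number here means a stronger inhibitor, a higher number a weaker inhibitor), giving > 100000 nM. Compound 2 `COc1cc(CC(COCc2ccccc2)COCc2ccccc2)nc(OC)n1` likewise reaches only the limit of this assay, giving > 100000 nM. For the measured compounds named here, compound 3 `COCn1c(CC(COCc2ccccc2)COCc2ccccc2)c(C)c(=O)[nH]c1=O` is the one member that returns a figure in this assay, giving 72100 nM, and so it stands alone as the only number among the values shown, the rest being described by the limit of > 100000 nM in this assay, at which 2 of the 3 values shown sit. Compound 4 `COCn1c(CC(COCc2ccccc2)COCc2ccccc2)c(C)c(=O)n(COC)c1=O` differs from compound 3 by methoxymethyl in place of hydrogen on an aromatic nitrogen, that is, a methoxymethyl in place of hydrogen on an aromatic nitrogen. No measured pair traces this change, so nothing shown tells how large a step it brings or in which direction. Compound 4 is expected to sit in this assay near 80000 nM, within a range from 30000 nM to 200000 nM. That estimate means a 1.1-fold higher number from compound 3 to compound 4 (0.05 log units; within the scatter), a step expected to stay within the usual scatter, with a real chance that only a limit is returned.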

Compound 4, half-maximal inhibitory concentration: 500 nM
Beside the measured number, compound 4's estimate is 160-fold (2.20 log units) above it; measured number below the stated range.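

In this assay, methoxymethyl in place of hydrogen on the aromatic nitrogen gives a 140-fold lower number from compound 3 to compound 4 (2.16 log units; beyond the scatter). For the compounds shown here, this is the first measured pair, and it shows that the shared core responds strongly to a change at this position, even though the entering group is no larger than methoxymethyl. Nothing shown gives a reason for the size of this step.

On these data alone, it remains open whether this step belongs to methoxymethyl itself or would also come with a plain methyl, a longer chain such as ethoxymethyl, or a chain ending in an amine on the same nitrogen. Going by these compounds alone, with only this one pair, it is also open whether the same change would carry over to the core of compound 1.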